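A few compounds are considered here, and "the series" means these few. Any claim that something is new, unique, unknown or untested is made for them only; others in the source may bear on it.

Working notes on the series, read in a functional assay on AGS cells (Homo sapiens) for antiproliferative activity, read by MTT assay, with a stated time of 48 h; on this read-out higher numbers stand for weaker inhibition of growth and lower numbers for stronger inhibition of growth. Compound 1 `COc1ccc(N(C)c2ncnc3c2ncn3C)cc1` gives > 100000 nM, which is a limit of the assay and not a number. Compound 2 `COc1ccc(N(C)c2nc(Cl)nc3[nH]cnc23)cc1` gives 30000 nM. Compound 3 `COc1ccc(N(C)c2nc(Cl)nc3c2ncn3C)cc1` gives 260 nM, the lowest number shown, and compound 2 is its nearest measured neighbour.

Two single changes lead to compound 3. Chloro in place of hydrogen on an aromatic carbon gives an at least 380-fold lower number from compound 1 to compound 3 (2.58 log units; beyond the scatter). Methyl in place of hydrogen on an aromatic nitrogen gives a 120-fold lower number from compound 2 to compound 3 (2.06 log units; beyond the scatter). Both steps are large.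

Compound 4 `COc1ccc(Cn2cnc3c(N(C)c4ccc(OC)cc4)nc(Cl)nc32)cc1` keeps the core of compound 3 and differs in one place: 4-methoxyphenyl in place of hydrogen on a saturated chain carbon bound to an aromatic nitrogen. The same difference reads methyl to 4-methoxybenzyl. The chloro step does not touch this place, so the methyl step is the one that bears on it. Among the measured compounds shown here, no measured compound carries a larger group here, so the direction is a judgement. Part of the gain seen in a 120-fold lower number from compound 2 to compound 3 (2.06 log units; beyond the scatter) is expected to be lost, giving a higher number in this assay, though a smaller step than that one. The estimated change is a 9.6-fold higher number from compound 3 to compound 4 (0.98 log units; beyond the scatter). For compound 4 the expected value is 2500 nM, with an estimated range of 300 nM to 25000 nM.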

Compound 4, concentration for 50% growth inhibition: > 100000 nM
Compound 4 gave a limit, no number (the forecaster's own chance of this, stated with the estimate: 10%); middle value at least 40-fold (1.60 log units) from the limit.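

At this place, on the saturated chain carbon bound to an aromatic nitrogen, the series does not keep its activity on going from methyl to 4-methoxybenzyl: in this assay, 4-methoxyphenyl in place of hydrogen gives an at least 380-fold higher number from compound 3 to compound 4 (2.58 log units; beyond the scatter), a step at least as large as either step leading to compound 3. The earlier compounds shown here showed only that methyl on the aromatic nitrogen gives a far lower number than hydrogen; the comparison with hydrogen now reverses for the larger group, with an at least 3.3-fold higher number from compound 2 to compound 4 (0.52 log units; beyond the scatter), so the gain is lost entirely and not in part, and a substituent here does not in itself bring the lower number. Compound 4 sits at a limit of the assay and not at a number, so both steps give only a minimum size, and the full extent of the loss cannot be read: the limit of > 100000 nM in this assay, at which 2 of the 4 values shown sit.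

The compounds shown leave open whether the loss already sets in with ethyl or a longer chain, or only with a benzyl group. They also leave open whether unsubstituted benzyl, or a chain ending in an amine or a carboxylic acid, would stay nearer to compound 3 260 nM.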